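Series notes: pyridine to pyrimidine on the amide carbonyl

The source may report more compounds than this note shows. Statements on the series, on what has been measured and on what is new or still open speak of the compounds shown alone.

Three analogues sharing one core have been measured in a functional assay on A549 cells (Homo sapiens) for antiproliferative activity, read by MTT assay, with a stated time of 72 h; a higher number here means a weaker inhibitor, a lower number a stronger inhibitor. Compound 1 `COc1cc(N(C)C)c(NC(=O)c2ccnc(Cl)c2)cc1Nc1nccc(-c2cn(C)c3ccccc23)n1` gives 3430 nM. Compound 2 `COc1ccc(C(=O)Nc2cc(Nc3nccc(-c4cn(C)c5ccccc45)n3)c(OC)cc2N(C)C)nc1` gives 5150 nM. Compound 3 `COc1cc(N(C)C)c(NC(=O)c2ccccn2)cc1Nc1nccc(-c2cn(C)c3ccccc23)n1` gives 8290 nM, the highest of the three numbers; its separation from compound 2 is within the scatter, that from compound 1 is beyond it, as a 2.4-fold higher number from compound 1 to compound 3 (0.38 log units; beyond the scatter) shows.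

Compound 4 `COc1cc(N(C)C)c(NC(=O)c2ccncn2)cc1Nc1nccc(-c2cn(C)c3ccccc23)n1` is not yet measured. It differs from compound 3 in one place: pyrimidin-4-yl in place of pyridin-2-yl on a carbonyl carbon.

Going by the values given here, no measured step swaps these two groups. The nearest comparisons concern the same carbonyl carbon: a 2.4-fold higher number from compound 1 to compound 3 (0.38 log units; beyond the scatter) and a 1.6-fold higher number from compound 2 to compound 3 (0.21 log units; within the scatter), and between compounds 1 and 2 a 1.5-fold higher number from compound 1 to compound 2 (0.18 log units; within the scatter). All three steps are small, and two of them fall inside the scatter, so exchanges of the aromatic group on this carbonyl have so far moved this assay little.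

On that basis no step beyond the scatter is expected from compound 3 to compound 4 in this assay, the expected step being a 1.0-fold lower number from compound 3 to compound 4 (0.02 log units; within the scatter). Among the compounds with values here, compound 4 is estimated at 8000 nM, with a range from 3000 nM to 20000 nM; the width reflects that the specific change has no direct precedent here.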

Compound 4, half-maximal inhibitory concentration: 5160 nM
For compound 4 the middle estimate is 1.6-fold (0.19 log units) above the measured one, within the range that was stated.
By their numbers in this assay, from the lowest: compounds 1, 2, 4 and 3 (each within the scatter of the next, the first and the last beyond it).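

In this assay, going by these compounds alone, pyrimidin-4-yl, the first group here with two ring hetero atoms on this carbonyl carbon, leaves the number within the scatter of the pyridin-2-yl group (a 1.6-fold lower number from compound 3 to compound 4 (0.21 log units; within the scatter)), so the change from one hetero atom to two, and from one hydrogen-bond acceptor to two, gives no readable separation at this position. Compound 4 also stays within the scatter of both substituted pyridine compounds (a 1.0-fold higher number from compound 2 to compound 4 (0.00 log units; within the scatter); a 1.5-fold higher number from compound 1 to compound 4 (0.18 log units; within the scatter)), which leaves the step between compound 1 and compound 3 (a 2.4-fold higher number from compound 1 to compound 3 (0.38 log units; beyond the scatter)) as the only one of the six beyond the scatter and the one exception to an otherwise flat set. No measurement available here explains this flatness or that single exception.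

Going by these compounds, the four groups on this carbonyl carbon are all six-membered aromatic rings, so it remains open whether a saturated amine such as piperidin-4-yl, a carboxylic acid or a longer alkyl chain there would shift the number by more. Also open, on these data alone, is whether pyrimidin-4-yl would carry a chloro or methoxy substituent without leaving the scatter, and how the series reads in any assay other than this one.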